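The compounds below may be only part of what the source reports. "The series", "measured", "known", "first", "only" and "open" are said of these compounds alone.

Among the compounds with values here, in an ADME assay on THP-1 cells (Homo sapiens) for cytotoxicity, read by flow cytometry and propidium iodide staining, with a stated time of 72 h (on this read-out lower numbers stand for stronger inhibition and higher numbers for weaker inhibition), compound 1 `CC(=O)Nc1ccc2oc(-c3ccccc3)c(O)c(=O)c2c1` gives 36000 nM and compound 2 `COc1ccc(-c2oc3ccc(NC(C)=O)cc3c(=O)c2O)cc1` gives 9000 nM, so compound 2 holds the lower of the two numbers so far. Compound 3 `CC(=O)Nc1ccc2oc(-c3ccccc3F)c(O)c(=O)c2c1` is not yet measured. It differs from compound 2 at one place, next to the ring oxygen, with 2-fluorophenyl in place of 4-methoxyphenyl on an aromatic carbon. Within the data shown here, the one measured step bearing on this is a 4.0-fold lower number from compound 1 to compound 2 (0.60 log units; beyond the scatter), a modest step with methoxy in place of hydrogen on an aromatic carbon. Among the measured compounds shown here, no measured compound carries fluorine, so that part of the change is untested. Going by compound 1 at 36000 nM, which also has no methoxy, a step of similar size towards a higher number is expected in this assay. The estimated step is a 3.1-fold higher number from compound 2 to compound 3 (0.49 log units; beyond the scatter). For compound 3 the expected value is 28000 nM, within an estimated range of 10000 nM to 80000 nM.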

Compound 3, half-maximal inhibitory concentration: 47000 nM
Compound 3: middle estimate off by 1.7-fold (0.22 log units), on the low side, within the range that was stated.
By their numbers in this assay, from the lowest: compound 2; then compounds 1 and 3 (each within the scatter of the next).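

In this assay, replacing 4-methoxyphenyl with 2-fluorophenyl on the aromatic carbon next to the ring oxygen gives a 5.2-fold higher number from compound 2 to compound 3 (0.72 log units; beyond the scatter), so the lower number of compound 2 is not kept with this group. Fluoro in place of hydrogen gives a 1.3-fold higher number from compound 1 to compound 3 (0.12 log units; within the scatter), which lies within the scatter, so among these three compounds only the 4-methoxyphenyl group sets a compound apart. Nothing available explains either step.

Since 2-fluorophenyl and 4-methoxyphenyl differ in both the substituent and where it sits on the phenyl ring, the compounds shown do not separate these two changes. As far as these compounds go, it also remains open how an ethoxy group, an amine or a carboxylic acid on that phenyl ring would read in this assay.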